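Swapping chloro for hydroxy in a weakly cytotoxic series

The source may hold more compounds than are shown below. What is called first, only, known or untested is meant among the compounds shown, and "the series" means these compounds.

Compound 1, `COc1cc(-c2nnc3n2NC(c2ccco2)C(C(=O)c2ccc(Cl)cc2)S3)cc(OC)c1OC`: in a functional assay on A549 cells (Homo sapiens) for cytotoxicity, read by MTT assay, with a stated time of 48 h (a higher number here means a weaker inhibitor, a lower number a stronger inhibitor), compound 1 gives 51400 nM. Compound 2, `COc1cc(-c2nnc3n2NC(c2cccs2)C(C(=O)c2ccccc2)S3)cc(OC)c1OC`: in this assay compound 2 gives 69400 nM. Compound 3, `COc1ccc(C(=O)C2Sc3nnc(-c4cc(OC)c(OC)c(OC)c4)n3NC2c2cccs2)cc1`: in this assay compound 3 gives > 100000 nM, which is a limit of the assay and not a number.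

Of the two numbers that were obtained, compound 1 and compound 2 sit within the usual scatter of each other, so neither can be called the stronger. The third value is a limit, and the limit of > 100000 nM in this assay, at which 1 of the 3 values shown sits, marks how many of the values end there.

Compound 4, `COc1cc(-c2nnc3n2NC(c2ccco2)C(C(=O)c2ccc(O)cc2)S3)cc(OC)c1OC`, is not yet measured. It differs from compound 1 in one place: hydroxy in place of chloro on an aromatic carbon. Within the data shown here, the only measured step between neighbours in this set is an at least 1.4-fold higher number from compound 2 to compound 3 (0.15 log units; that floor lies within the scatter), a change on the same carbon-only ring but of a different group, and its size is only a floor that lies within the scatter. No measured step therefore speaks directly to hydroxy in place of chloro, and nothing in the shared core has been shown to shift the read-out beyond the scatter.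

On that basis compound 4 is expected to land near compound 1, with a 1.2-fold higher number from compound 1 to compound 4 (0.07 log units; within the scatter) as the estimated step. The estimate for compound 4 in this assay is 60000 nM, within a range from 25000 nM to 150000 nM.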

Compound 4, half-maximal inhibitory concentration: 93400 nM
Compound 4: the middle estimate sits 1.6-fold (0.19 log units) below what was measured, within the range that was stated.
By their numbers in this assay, from the lowest: compounds 1, 2 and 4 (each within the scatter of the next). At a limit, above all of these: compound 3.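

Among these compounds, compound 1 and compound 4 give the first step at this place on the ring that has a number at both ends, as the earlier step carried only a floor. In this assay, the exchange of 4-chlorophenyl for 4-hydroxyphenyl gives a 1.8-fold higher number from compound 1 to compound 4 (0.26 log units; within the scatter). This exchange brings in a hydrogen-bond donor and a hydrogen-bond acceptor where chloro has neither, yet the two compounds cannot be told apart, so this change at this place has no effect that can be read beyond ordinary repeat variation. Compound 3 remains a limit and not a number, and it is the only compound of the four that does: the limit of > 100000 nM in this assay, at which 1 of the 4 values shown sits.

As far as these compounds go, whether any group on this carbon can move the number beyond the scatter stays open, and an amine or a carboxylic acid in place of the hydroxy would be a direct test. From the compounds shown here alone, it also remains open whether hydroxy in place of chloro reads the same way on the core of compound 2, which differs from compound 1 in the other ring as well.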